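The compounds below may be only part of what the source reports. "The series", "measured", "known", "first", "only" and "open" are said of these compounds alone.

Working notes on the series. Compound 1 `Cc1cc(NC(=O)Cn2nnc(-c3ccccc3)n2)n(C2CCCCC2)n1` is the point of departure here. Going by the values given here, in an assay on HEK293 cells for activation of Kir3.1/Kir3.2 (Homo sapiens), read by thallium flux (on this read-out higher numbers stand for larger maximal responses and lower numbers for smaller maximal responses), compound 1 gives 92%, the lower of the two numbers measured so far. Compound 2 `Cc1cc(NC(=O)Cn2nnc(-c3ccccc3)n2)n(C2CCCC2)n1` differs from it only by cyclopentyl in place of cyclohexyl on an aromatic nitrogen; in this assay compound 2 gives 105%, and the step between them is a number 13 percentage points higher from compound 1 to compound 2 (beyond the scatter).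

Compound 3 `Cc1cc(NC(=O)Cn2nnc(-c3cccnc3)n2)n(C2CCCCC2)n1` has not been measured. It differs from compound 1 at another site: pyridin-3-yl in place of phenyl on an aromatic carbon. Among the compounds with values here, no measured step touches the group on the aromatic carbon of the five-membered aromatic ring with 4 nitrogen; the one step in hand, a number 13 percentage points higher from compound 1 to compound 2 (beyond the scatter), concerns the group on the aromatic nitrogen and gives no guide to the exchange of phenyl for pyridin-3-yl. The expectation therefore rests on the value of compound 1 alone, and no move beyond the scatter is expected in this assay in either direction, with a wide range to cover the lack of a comparable step. The step this expectation implies is a number 2 percentage points lower from compound 1 to compound 3 (within the scatter). Compound 3 is estimated at 90% in this assay, within a range from 65% to 110%.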

Compound 3, largest response reached (Emax), in percent of the reference or control that the assay uses: 96%
Beside the measured number, compound 3's estimate is 6 percentage points below it, within the range that was stated.
By their numbers in this assay, from the lowest: compounds 1, 3 and 2 (each within the scatter of the next, the first and the last beyond it).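

The phenyl group on the aromatic carbon of the five-membered aromatic ring with 4 nitrogen can be replaced by pyridin-3-yl with a number 4 percentage points higher from compound 1 to compound 3 (within the scatter) in this assay, so this first measured exchange at the position leaves the maximal response unresolved from that of compound 1. The change keeps the heavy-atom count of the group and adds the hydrogen-bond acceptor counted for pyridin-3-yl, and on this read-out that exchange of a ring carbon for a ring nitrogen has no effect that can be told from the scatter. No evidence at hand bears on this result or offers an account of it.

The compounds shown leave open whether other groups at this aromatic carbon, such as pyridin-4-yl or a phenyl carrying an amine or a carboxylic acid, would also stay within the scatter of compound 1. They also leave open whether pyridin-3-yl can be combined with cyclopentyl on the aromatic nitrogen, the change that gave a number 13 percentage points higher from compound 1 to compound 2 (beyond the scatter), and what either change does to any read-out other than the maximal response.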